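The source may report more compounds than this note shows. Statements on the series, on what has been measured and on what is new or still open speak of the compounds shown alone.

Compound 1, `O=C1c2c[n+]([O-])c3ccccc3c2C(=O)c2c1c1ccccc1n2Cc1cn(C[C@H](O)CO)nn1`, gives > 1000 nM in a functional assay on MCF7 cells (Homo sapiens) for cytotoxicity, read by MTT assay, with a stated time of 72 h (on this read-out higher numbers stand for weaker inhibition and lower numbers for stronger inhibition), a limit rather than a number. Compound 2, `CCCCN1CCN(CCCCn2c3c(c4ccccc42)C(=O)c2c[n+]([O-])c4ccccc4c2C3=O)CC1`, gives 6900 nM. Compound 3, `CC1(C)OC[C@H](Cn2cc(Cn3c4c(c5ccccc53)C(=O)c3c[n+]([O-])c5ccccc5c3C4=O)nn2)O1`, gives 530 nM.

Compound 3 thus stands lowest of the two numbers, with compound 2 the nearest and higher by a gap beyond the scatter; the value of compound 1 is only a limit (the limit of > 1000 nM in this assay, at which 1 of the 3 values shown sits). Compound 4, `O=C1c2c[n+]([O-])c3ccccc3c2C(=O)c2c1c1ccccc1n2Cc1cn(C[C@@H](O)CO)nn1`, differs from compound 3 in one place: 1,2-dihydroxyethyl in place of 2,2-dimethyl-1,3-dioxolan-4-yl on a saturated chain carbon bound to an aromatic nitrogen. For the measured compounds named here, the single measured step that bears on this is the reverse change, an at least 1.8-fold lower number from compound 1 to compound 3 (0.27 log units; that floor lies within the scatter), where compound 1 reached only a limit. A rise in this assay is therefore expected for compound 4, a 2.8-fold higher number from compound 3 to compound 4 (0.45 log units; beyond the scatter), quite possibly ending at a limit again. Compound 4 is estimated at 1500 nM, within 500 nM to 5000 nM.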

Compound 4, half-maximal inhibitory concentration: 600 nM
Compound 4: the middle estimate sits 2.5-fold (0.40 log units) above what was measured, and the stated range covers the measured number.
By their numbers in this assay, from the lowest: compounds 3 and 4 (each within the scatter of the next); then compound 2.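

At this position on a saturated chain carbon bound to an aromatic nitrogen, 1,2-dihydroxyethyl and 2,2-dimethyl-1,3-dioxolan-4-yl give values within the scatter of each other in this assay: a 1.1-fold higher number from compound 3 to compound 4 (0.05 log units; within the scatter). Compound 1 reaches only a limit: the limit of > 1000 nM in this assay, at which 1 of the 4 values shown sits. The other new step reads an at least 1.6-fold lower number from compound 1 to compound 4 (0.22 log units; that floor lies within the scatter), a floor that does not settle whether the configuration at the chain stereocentre matters: the fact that compounds 1 and 4 differ only in the configuration as drawn

As far as these compounds go, it remains open whether an amine, a carboxylic acid or a longer chain at this position would give a different number in this assay.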